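A few compounds are considered here, and "the series" means these few. Any claim that something is new, unique, unknown or untested is made for them only; others in the source may bear on it.

Measured so far in a functional assay on MDA-MB-453 cells (Homo sapiens) for cytotoxicity, read by MTT assay, with a stated time of 72 h; a lower number here means a stronger inhibitor, a higher number a weaker inhibitor:
- compound 1 `CC(C)(C)C1=CC(=O)C=C(NCC(=O)O)C1=O`: 171000 nM
- compound 2 `CC1=CCC[C@H]2[C@](C)(CC3=CC(=O)C=C(N[C@@H](CC(C)C)C(=O)O)C3=O)[C@@H](C)CC[C@]12C`: 10900 nM
- compound 3 `CC(C)[C@@H](NC1=CC(=O)C=C(C(C)(C)C)C1=O)C(=O)O`: 133000 nM

Compound 1 at 171000 nM stands level with compound 3 within the scatter, while compound 2 shows a clearly lower number at 10900 nM. Compound 4 `C[C@H](NC1=CC(=O)C=C(C(C)(C)C)C1=O)C(=O)O` differs from compound 1 by methyl in place of hydrogen on a saturated chain carbon bound to an amine nitrogen and a carbonyl carbon. Among the measured compounds shown here, one measured step bears on this, isopropyl at that same place, and a 1.3-fold lower number from compound 1 to compound 3 (0.11 log units; within the scatter) stays within the scatter. Compound 2 differs from compound 1 in more than one place and gives no direct guide. In this assay no change beyond the scatter is therefore expected, and the estimated 1.1-fold lower number from compound 1 to compound 4 (0.06 log units; within the scatter) is small. Compound 4 is estimated at 150000 nM with an expected range from 90000 nM to 240000 nM.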

Compound 4, half-maximal inhibitory concentration: 112000 nM
Compound 4: the middle estimate sits 1.3-fold (0.13 log units) above what was measured; the measured number falls inside the stated range.
By their numbers in this assay, from the lowest: compound 2; then compounds 4, 3 and 1 (each within the scatter of the next).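

In this assay, methyl at this saturated chain carbon bound to an amine nitrogen and a carbonyl carbon gives a 1.5-fold lower number from compound 1 to compound 4 (0.18 log units; within the scatter). Alongside a 1.3-fold lower number from compound 1 to compound 3 (0.11 log units; within the scatter), this shows that a second, single-carbon group at the same place also stays within the scatter, so neither methyl nor isopropyl separates from hydrogen here. No available measurement explains this result. From the compounds shown here alone, it remains open whether a benzyl group or a chain carrying an amine at this place would move the number beyond the scatter. Going by these compounds, compound 2 differs from compound 1 in more than one place, so which of its differences goes with its lower number also remains open.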